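A few compounds are considered here, and "the series" means these few. Any claim that something is new, unique, unknown or untested is made for them only; others in the source may bear on it.

Compound 1 `Nc1ccccc1NC(=O)c1ccc(CSC(=S)N2CCN(c3ccc(Cl)cc3)CC2)cc1` is the weakest of the three compounds measured in a functional assay on MGC-803 cells (Homo sapiens) for antiproliferative activity, read by CCK-8 assay, with a stated time of 72 h, tested at 2 uM (a lower number here means a weaker effect, a higher number a stronger effect of the compound at the concentration tested), where compound 1 gives 15%. Compound 2 `CC1CCCCN1C(=S)SCc1ccc(C(=O)Nc2ccccc2N)cc1` gives 64.4% and compound 3 `Nc1ccccc1NC(=O)c1ccc(CSC(=S)N2CCc3cc(Cl)ccc32)cc1` gives 57.7%, both beyond the scatter above compound 1. For the measured compounds named here, the one measured step, a number 6.7 percentage points lower from compound 2 to compound 3 (within the scatter), swaps the group on the thiocarbonyl carbon and stays within the scatter. Compound 4 `Nc1ccccc1NC(=O)c1ccc(CSC(=S)N2CCN(c3cccnc3)CC2)cc1` differs from compound 1 by pyridin-3-yl in place of 4-chlorophenyl on an amine nitrogen in a ring. Going by the values given here, no measured step touches this part of the shared core, so the only guide is compound 1 itself and its low value. I therefore expect for compound 4 a value of 25% in this assay, between 5% and 50%, meaning an expected step of a number 10 percentage points higher from compound 1 to compound 4 (within the scatter) that could well sit within the scatter.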

Compound 4, a percentage reported as inhibition, at one concentration (the size of the read-out at that concentration, not a potency): 27.6%
Beside the measured number, compound 4's estimate is 2.6 percentage points below it; low and high end bracket the measured number.
By their numbers in this assay, from the lowest: compound 1; then compound 4; then compounds 3 and 2 (each within the scatter of the next).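

On the amine nitrogen in the ring, the change to pyridin-3-yl gives a modest gain in this assay, a number 12.6 percentage points higher from compound 1 to compound 4 (beyond the scatter). This step shows that the group at this position can shift the read-out beyond the scatter, here with a ring carrying one hydrogen-bond acceptor replacing a chlorine-bearing carbon ring. Nothing available explains the rise. The compounds shown leave open whether the gain follows from adding the ring nitrogen or from losing the chlorine. A plain phenyl group on the same amine nitrogen would separate these two changes.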